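Sulfonyl aryl swap on the bipiperidine sulfonamide core

The compounds below may be only part of what the source reports. "The series", "measured", "known", "first", "only" and "open" are said of these compounds alone.

Measured compounds and their values:
compound 1 `Cc1noc(C)c1S(=O)(=O)N1CCC(N2CCC(C)CC2)CC1`, > 5000 nM; compound 2 `Cc1nc(Cl)sc1S(=O)(=O)N1CCC(N2CCC(C)CC2)CC1`, 1.6 nM; compound 3 `CC1CCN(C2CCN(S(=O)(=O)c3cn(C)cn3)CC2)CC1`, > 5000 nM.

In a functional assay on DLD-1 cells (Homo sapiens) for antiproliferative activity, read by CellTiter-Glo, with a stated time of 72 h (a lower number here means a stronger inhibitor, a higher number a weaker inhibitor), compound 2 gives 1.6 nM. Compound 1 gives only a limit of the assay, > 5000 nM. Compound 3 likewise gives only a limit, > 5000 nM, so compound 3 stands at the weak end of the numbers shown, with the limit of > 5000 nM in this assay, at which 2 of the 3 values shown sit, marking where two of the three values sit. Among the compounds with values here, the one readable step is an at least 3100-fold lower number from compound 1 to compound 2 (3.49 log units; beyond the scatter); in the other direction an at least 3100-fold higher number from compound 2 to compound 3 (3.49 log units; beyond the scatter) is equally large, and a step that the two limits leave unreadable from compound 1 to compound 3 cannot be read from two limits.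

Compound 4 `CC1CCN(C2CCN(S(=O)(=O)c3ccc(F)cc3F)CC2)CC1` is not yet measured. It differs from compound 3 by 2,4-difluorophenyl in place of 1-methyl-1H-imidazol-4-yl on a sulfonyl sulfur. Within the data shown here, no measured step exchanges a heteroaryl for a carbon-only aromatic ring on the sulfonyl sulfur, so the measured steps bear on it only by showing that this position swings this assay over a very wide span. Given that span, and that compound 3 sits at a limit, the number for compound 4 is expected to be lower than that of compound 3, with the step estimated as an at least 10-fold lower number from compound 3 to compound 4 (1.00 log units; beyond the scatter). Compound 4 is estimated at 500 nM in this assay, within a range of 20 nM to 5000 nM.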

Compound 4, half-maximal inhibitory concentration: 102 nM
Beside the measured number, compound 4's estimate is 4.9-fold (0.69 log units) above it, and the stated range covers the measured number.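

In this assay, 2,4-difluorophenyl on the sulfonyl sulfur gives an at least 49-fold lower number from compound 3 to compound 4 (1.69 log units; beyond the scatter) and an at least 49-fold lower number from compound 1 to compound 4 (1.69 log units; beyond the scatter), so a readable number at this position is not confined to 2-chloro-4-methyl-1,3-thiazol-5-yl, and a carbon-only aromatic ring can also supply one. Both of these steps start from a limit of the assay and give only a minimum size: the limit of > 5000 nM in this assay, at which 2 of the 4 values shown sit. The position also now shows an intermediate level rather than only two extremes, with a 64-fold higher number from compound 2 to compound 4 (1.80 log units; beyond the scatter), so 2-chloro-4-methyl-1,3-thiazol-5-yl remains clearly ahead of 2,4-difluorophenyl in this series.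

With only two readable numbers, and with the rings differing in several features at once, the compounds shown do not tell which feature of either ring accounts for the difference between them. On these data alone, it remains open whether both fluorines are needed, and where an unsubstituted phenyl, a 4-fluorophenyl, a 2,4-dichlorophenyl or a pyridine ring on the sulfonyl sulfur would fall on this span.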